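The compounds below may be only part of what the source reports. "The series", "measured", "known", "first", "only" and "open" are said of these compounds alone.

Compound 1 `COC(C)CO[C@H](CC=C(C)C)C1=CC(=O)c2c(O)ccc(O)c2C1=O` and compound 2 `CC(=O)OC(C)CO[C@H](CC=C(C)C)C1=CC(=O)c2c(O)ccc(O)c2C1=O` share one core and differ only in the chain on the ether oxygen. In a functional assay on DU-145 cells (Homo sapiens) for cytotoxicity, read by MTT assay (a higher number here means a weaker inhibitor, a lower number a stronger inhibitor), compound 1 gives 16600 nM, and compound 2 gives 16600 nM, so the step of no change at the digits printed from compound 1 to compound 2 (within the scatter) is flat and compound 2 stands level with compound 1. Compound 3 `CCC(CO[C@H](CC=C(C)C)C1=CC(=O)c2c(O)ccc(O)c2C1=O)OC` carries the change (1-methoxypropyl in place of 1-acetoxyethyl on a saturated chain carbon bound to an oxygen on a saturated carbon). Within the data shown here, the single step that bears on it, swapping acetyl for methyl at the same chain, produced nothing beyond the scatter, so no shift beyond the scatter is expected for the step of no change at the digits printed from compound 2 to compound 3 (within the scatter). Compound 3 is therefore estimated at 16600 nM, between 8000 nM and 35000 nM.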

Compound 3, half-maximal inhibitory concentration: 45700 nM
Estimate against measurement, compound 3: 2.8-fold (0.44 log units) below; measured number above the stated range.
By their numbers in this assay, from the lowest: compounds 1 and 2 (each within the scatter of the next); then compound 3.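

In this assay, the chain on the ether oxygen proves responsive: methyl in place of hydrogen on a saturated chain carbon, two bonds along the chain from an oxygen on a saturated carbon, gives a modest weakening (a 2.8-fold higher number from compound 1 to compound 3 (0.44 log units; beyond the scatter)). The change from 1-acetoxyethyl to 1-methoxypropyl gives the same modest weakening (a 2.8-fold higher number from compound 2 to compound 3 (0.44 log units; beyond the scatter)), whereas the acetyl-for-methyl swap alone gave none (no change at the digits printed from compound 1 to compound 2 (within the scatter)). No measurement here explains this weakening. On these data alone, whether a longer chain, such as 2-methoxypentyl, would weaken the compound further remains open. So does the effect of an amine on this chain.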